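The compounds below may be only part of what the source reports. "The series", "measured", "known", "first", "only" and "open" are said of these compounds alone.

Three compounds have so far been measured in an ADME assay on the whole organism (strain Sprague-Dawley) for pharmacokinetics, with Rattus norvegicus as the target, using cassette dosing; a higher number here means faster removal of the compound, a lower number slower removal:

Compound 1 `O=c1ccc(-c2cc(C[C@]3(O)CC[C@@H](Cc4ccc(Cl)cc4)CC3)no2)c[nH]1`: 16.8 mL/min/kg
Compound 2 `O[C@]1(Cc2cc(-c3cn[nH]c3)on2)CC[C@H](Cc2ccc(Cl)cc2)CC1`: 11.7 mL/min/kg
Compound 3 `O[C@]1(Cc2cc(-c3cn[nH]c3)on2)CC[C@H](Cc2ccc(C(F)(F)F)cc2)CC1`: 4 mL/min/kg

Compound 2 stands second highest of these three numbers. Its neighbour is compound 1, with a 1.4-fold lower number from compound 1 to compound 2 (0.16 log units; within the scatter), a gap that stays within the scatter, so the two cannot be ranked against each other. The larger gap is a 2.9-fold lower number from compound 2 to compound 3 (0.47 log units; beyond the scatter), a modest but real slowing of removal when trifluoromethyl replaces chloro on the aromatic ring.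

Compound 4 `O[C@]1(Cc2cc(-c3cn[nH]c3)on2)CC[C@H](Cc2ccc(F)c(F)c2)CC1` is the next compound. It differs from compound 2 in one place: 3,4-difluorophenyl in place of 4-chlorophenyl on a saturated chain carbon bound to a saturated ring carbon. Going by the values given here, of the two measured steps, only the one from compound 2 to compound 3 touches the same ring, and it replaced chloro with a different group, so no measured pair shows exactly this swap. The step from compound 1 to compound 2 changed another part of the molecule and does not bear on it. Among the compounds with values here, with that modest slowing as the only guide, the step of a 1.3-fold lower number from compound 2 to compound 4 (0.11 log units; within the scatter) is expected to stay within the scatter, leaning slightly toward slower removal. For compound 4 the estimate in this assay is 9 mL/min/kg, with a range from 4.5 mL/min/kg to 18 mL/min/kg.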

Compound 4, clearance: 15.2 mL/min/kg
Compound 4: the middle estimate sits 1.7-fold (0.23 log units) below what was measured; the measured number falls inside the stated range.
By their numbers in this assay, from the lowest: compound 3; then compounds 2, 4 and 1 (each within the scatter of the next).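

In this assay, 3,4-difluorophenyl in place of 4-chlorophenyl gives a 1.3-fold higher number from compound 2 to compound 4 (0.11 log units; within the scatter), so on a saturated chain carbon bound to a saturated ring carbon, this swap cannot be told apart from no change. Going by these compounds alone, until now, the only change at this place was trifluoromethyl for chloro, which lowered the number beyond the scatter; this result shows that replacing the chloro-bearing ring does not always do that, as compound 3 stands at 4 mL/min/kg and compound 4 at 15.2 mL/min/kg. Nothing available explains why these groups give such different numbers.

From the compounds shown here alone, how a nitrile or a methoxy group on this ring would behave remains open. Going by these compounds, it is also open whether 3,4-difluorophenyl would give a similar result on the core of compound 1.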